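This account rests on a few compounds, and the source may have more. Where it says the series, first, only, none or still open, it means among the compounds named here.

Compound 1, `C[C@@H](NCc1ccc(Cl)cc1)[C@H]1CC[C@@H](c2ccnc3ccc(F)cc32)CC1`: in an assay on blood for inhibition of Indoleamine 2,3-dioxygenase 1 (Homo sapiens), read by mass spectrometry, with stated times of 4 h and 18 h (a lower number here means a stronger inhibitor, a higher number a weaker inhibitor), compound 1 gives > 1000 nM, which is a limit of the assay.
Compound 2, `C[C@@H](NS(=O)(=O)c1ccc(Cl)cc1)[C@H]1CC[C@@H](c2ccnc3ccc(F)cc32)CC1`: in this assay compound 2 gives 484 nM.
Compound 3, `C[C@@H](NC(=O)Nc1ccc(Cl)cc1)[C@H]1CC[C@@H](c2ccnc3ccc(F)cc32)CC1`: in this assay compound 3 gives 280 nM.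

Compound 3 holds the lowest of the two numbers, but the nearest step is a 1.7-fold lower number from compound 2 to compound 3 (0.24 log units; within the scatter), and compound 1 sits at a limit (the limit of > 1000 nM in this assay, at which 1 of the 3 values shown sits). Compound 4, `C[C@@H](NC(=O)C12CCC(Cl)(CC1)CC2)[C@H]1CC[C@@H](c2ccnc3ccc(F)cc32)CC1`, differs from compound 3 by a group of 9 heavy atoms (8 carbon, 1 chlorine; 2 six-membered non-aromatic rings of carbon only) in place of a group of 8 heavy atoms (6 carbon, 1 nitrogen, 1 chlorine; one six-membered aromatic ring of carbon only), on a carbonyl carbon. The measured steps of an at least 3.5-fold lower number from compound 1 to compound 3 (0.55 log units; beyond the scatter) and an at least 2.0-fold lower number from compound 1 to compound 2 (0.31 log units; beyond the scatter) both alter the group on the amine nitrogen, not the carbonyl side, so none bears directly on this change. No step beyond the scatter is expected in this assay. Compound 4 is therefore estimated at 400 nM, between 120 nM and 1500 nM, an expected step of a 1.4-fold higher number from compound 3 to compound 4 (0.15 log units; within the scatter).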

Compound 4, half-maximal inhibitory concentration: 579 nM
Compound 4: the middle estimate sits 1.4-fold (0.16 log units) below what was measured, within the range that was stated.
By their numbers in this assay, from the lowest: compounds 3, 2 and 4 (each within the scatter of the next, the first and the last beyond it). At a limit, above all of these: compound 1.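

In this assay, keeping the carbonyl and changing only the group on it gives a 2.1-fold higher number from compound 3 to compound 4 (0.32 log units; beyond the scatter), the first step shown at this carbonyl carbon. The change removes an aromatic ring and a hydrogen-bond donor together, so the step cannot be assigned to either one alone. Nothing shown accounts for the step.

Still open, going by these compounds, is how a 4-chlorophenyl group set directly on the carbonyl carbon, which removes only the donor, would compare. The same holds for a (4-chlorocyclohexyl)amino group, which removes only the aromatic ring.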